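A few compounds are considered here, and "the series" means these few. Any claim that something is new, unique, unknown or untested is made for them only; others in the source may bear on it.

In a functional assay on HeLa cells (Homo sapiens) for antiproliferative activity, read by MTT assay, with a stated time of 48 h (on this read-out lower numbers stand for stronger inhibition and higher numbers for weaker inhibition), compound 2 `Clc1cc2nc(-c3cn(-c4ccccc4)nc3-c3ccccc3)[nH]c2cc1Cl` gives 13400 nM. Compound 3 `COc1ccc2[nH]c(-c3cn(-c4ccccc4)nc3-c3ccc(F)cc3)nc2c1` gives 7510 nM, which lies within the usual scatter of the value for compound 2. Compound 1 `Clc1ccc2[nH]c(-c3cn(-c4ccccc4)nc3-c3ccccc3)nc2c1` gives 3480 nM, and the measured step that links this pair is a 3.9-fold higher number from compound 1 to compound 2 (0.59 log units; beyond the scatter), a modest move beyond the scatter that comes with chloro in place of hydrogen on an aromatic carbon.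

Compound 4 `Fc1ccc(-c2nn(-c3ccccc3)cc2-c2nc3cc(Cl)c(Cl)cc3[nH]2)cc1` keeps the rest of compound 2 and changes one place: fluoro in place of hydrogen on an aromatic carbon. This is fluoro in place of hydrogen on an aromatic carbon, para to a large group, so phenyl becomes 4-fluorophenyl.

The chloro step is a different change at a different place, so it sets no size for this one. Compound 3 also carries 4-fluorophenyl, but it has no measured partner that differs only by that group. With no measured evidence for a shift, no step beyond the scatter is expected in this assay. The expected change is a 1.2-fold lower number from compound 2 to compound 4 (0.09 log units; within the scatter). For compound 4 the estimated value is 11000 nM, with an expected range from 4500 nM to 27000 nM.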

Compound 4, half-maximal inhibitory concentration: 11600 nM
Compound 4: the middle estimate sits 1.1-fold (0.02 log units) below what was measured; measured number inside the range.
By their numbers in this assay, from the lowest: compound 1; then compounds 3, 4 and 2 (each within the scatter of the next).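

Going from phenyl to 4-fluorophenyl gives a 1.2-fold lower number from compound 2 to compound 4 (0.06 log units; within the scatter) in this assay and so leaves the reading unmoved within the scatter, which means that with this shared core a fluoro on this aromatic carbon, para to a large group, makes no visible difference. Among the compounds shown here, the earlier compounds could not show this: compound 3 also carries 4-fluorophenyl, but it has no partner differing only by that group, so this pair is the only direct reading of the change. Nothing measured here speaks to why the fluoro leaves so little mark.

One pair cannot say whether the same change would read alike on the core of compound 1, which carries a single chloro. It also leaves open whether an amine, a carboxylic acid or a longer chain such as butyl at this place would leave the number equally unmoved.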